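The source may hold more compounds than are shown below. What is called first, only, known or untested is meant among the compounds shown, and "the series" means these compounds.

Of the compounds shown here, three of one family have been tested in a functional assay on cells (Leukemia cell, Homo sapiens) for cytotoxicity, read by sulforhodamine B assay, with a stated time of 48 h; on this read-out higher numbers stand for weaker inhibition of growth and lower numbers for stronger inhibition of growth. Compound 1 `Oc1ccc(O)c(-c2cc(-c3ccc(Cl)cc3)nn2-c2ccccc2)c1` gives 49700 nM. Compound 3 `O=C1C=CC(=O)C(c2cc(-c3ccc(Cl)cc3)nn2-c2ccccc2)=C1` gives 87100 nM, and the step of a 1.8-fold higher number from compound 1 to compound 3 (0.24 log units; within the scatter) is the change (a group of 8 heavy atoms (6 carbon, 2 oxygen; one six-membered non-aromatic ring of carbon only) in place of a group of 8 heavy atoms (6 carbon, 2 oxygen; one six-membered aromatic ring of carbon only), on an aromatic carbon). Compound 2 `CC(=O)NS(=O)(=O)c1ccc(-n2nc(-c3ccccc3)cc2-c2cc(O)ccc2O)cc1` gives 100000 nM; the difference between the cores of compound 2 and compound 1 is not broken down here. Compound 4 `CC(=O)NS(=O)(=O)c1ccc(-n2nc(-c3ccccc3)cc2C2=CC(=O)C=CC2=O)cc1` is the change a group of 8 heavy atoms (6 carbon, 2 oxygen; one six-membered non-aromatic ring of carbon only) in place of a group of 8 heavy atoms (6 carbon, 2 oxygen; one six-membered aromatic ring of carbon only), on an aromatic carbon made on compound 2. For the measured compounds named here, this is the same kind of change as the one from compound 1 to compound 3, not the same: here the new group sits next to the ring atom that bears a large group and two ring bonds from the ring atom that bears a phenyl group, whereas before it sat next to the ring atom that bears a phenyl group and two ring bonds from the ring atom that bears a 4-chlorophenyl group. Because the step of a 1.8-fold higher number from compound 1 to compound 3 (0.24 log units; within the scatter) stayed within the scatter, a step of similar size, no change at the digits printed from compound 2 to compound 4 (within the scatter), is expected for compound 4. Compound 4 is therefore estimated at 100000 nM, between 50000 nM and 200000 nM, in this assay.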

Compound 4, concentration for total growth inhibition: 91200 nM
For compound 4 the middle estimate is 1.1-fold (0.04 log units) above the measured one; low and high end bracket the measured number.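

In this assay, putting the non-aromatic ring group in place of the 2,5-dihydroxyphenyl group gives a 1.1-fold lower number from compound 2 to compound 4 (0.04 log units; within the scatter). Set beside the earlier case, the change reads the same on both cores, with no difference that can be told from the scatter: the same change on two cores in this assay, a 1.8-fold higher number (0.24 log units; within the scatter) from compound 1 to compound 3 and a 1.1-fold lower number (0.04 log units; within the scatter) from compound 2 to compound 4, 1.9-fold (0.28 log units) apart, within the scatter of two such steps. For the compounds shown here, this shows only that the change left the number within the scatter on these two cores in this one cell test; it does not show that the two groups are interchangeable on other cores or in other tests.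

The compounds shown leave open how a 2,5-dimethoxyphenyl group would compare with these two groups. They also leave open whether the change reads the same on a core with an amine or a carboxylic acid in place of the chlorine of compound 1.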